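Cytotoxicity in the series: an aryl swap on the core

A few compounds are considered here, and "the series" means these few. Any claim that something is new, unique, unknown or untested is made for them only; others in the source may bear on it.

Two compounds of the series have been run in an ADME assay on MT4 cells (Homo sapiens) for cytotoxicity, read by MTT assay; on this read-out higher numbers stand for lower toxicity in this test and lower numbers for higher toxicity in this test. Compound 1 `COc1ccc(-c2c(C)nc(NC(=O)NC3CCCCC3)c(C)c2C(OC(C)(C)C)C(=O)O)cc1` gives 19000 nM in this assay, and compound 2 `Cc1nc(NC(=O)NC2CCCCC2)c(C)c(C(OC(C)(C)C)C(=O)O)c1-c1ccc2c(c1)CCCO2` gives 17000 nM. Among the measured compounds shown here, on these two numbers compound 2 stands lowest, with compound 1 as its only neighbour; the step of a 1.1-fold lower number from compound 1 to compound 2 (0.05 log units; within the scatter) is within the scatter, so the two read as equivalent.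

Compound 3 `Cc1nc(NC(=O)NC2CCCCC2)c(C)c(C(OC(C)(C)C)C(=O)O)c1-c1ccc(C(F)(F)F)cc1` is not yet measured. It differs from compound 2 by a group of 10 heavy atoms (7 carbon, 3 fluorine; one six-membered aromatic ring of carbon only) in place of a group of 10 heavy atoms (9 carbon, 1 oxygen; one six-membered non-aromatic ring with 1 hetero atom, one six-membered aromatic ring of carbon only), on an aromatic carbon, a 4-(trifluoromethyl)phenyl group entering where the group of 10 heavy atoms with one six-membered non-aromatic ring with 1 hetero atom leaves. For the measured compounds named here, the only measured step that bears on this position is the one from compound 1 to compound 2, an exchange of the group on the same aromatic carbon, and it moved the number by a 1.1-fold lower number from compound 1 to compound 2 (0.05 log units; within the scatter). Going by the values given here, with that as the sole precedent, the expected step in this assay is a 1.1-fold higher number from compound 2 to compound 3 (0.02 log units; within the scatter), nothing beyond the scatter. Compound 3 is therefore estimated at 18000 nM, with a range from 8000 nM to 40000 nM.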

Compound 3, half-maximal cytotoxic concentration: 9800 nM
Compound 3: the middle estimate sits 1.8-fold (0.26 log units) above what was measured, and the stated range covers the measured number.
By their numbers in this assay, from the lowest: compounds 3, 2 and 1 (each within the scatter of the next).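

On the aromatic carbon para to the (cyclohexylcarbamoyl)amino group, this assay now covers a third aryl group, and the new compound shows a 1.7-fold lower number from compound 2 to compound 3 (0.24 log units; within the scatter) and a 1.9-fold lower number from compound 1 to compound 3 (0.29 log units; within the scatter) so 4-(trifluoromethyl)phenyl reads as equivalent to both earlier groups. The two earlier groups both carry an oxygen, whereas 4-(trifluoromethyl)phenyl has no oxygen and no hydrogen-bond acceptor, so an oxygen in this group is not required for a number in this range, at least across these three compounds. Nothing on hand offers a reason for these readings.

All three groups at this position are aryl groups, so it remains open whether an amine, a hydroxyl group or a longer alkyl chain on this carbon would stay within the scatter of these compounds. As far as these compounds go, the carboxy(tert-butoxy)methyl and (cyclohexylcarbamoyl)amino groups are the same throughout, so it is also open whether this flat reading at the aryl position would hold if either of them were exchanged.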